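This account rests on a few compounds, and the source may have more. Where it says the series, first, only, none or still open, it means among the compounds named here.

Measured compounds:
compound 1, `CCCc1c(COc2ccc(C(=O)CCC(=O)O)cc2)ccc(C(C)=O)c1O`: 18.2 mg/kg
compound 2, `CCCc1c(COc2ccc(C(=O)C(C)Cc3nnn[nH]3)cc2)ccc(C(C)=O)c1O`: 9.2 mg/kg
compound 3, `CCCc1c(COc2ccc(C(=O)CCCc3nnn[nH]3)cc2)ccc(C(C)=O)c1O`: 7.2 mg/kg

In an in vivo functional assay on the whole organism (Rattus norvegicus) with cysteinyl leukotriene receptor (Homo sapiens) as the target (a higher number here means that more compound is needed for the effect, a lower number that less compound is needed), compound 3 gives 7.2 mg/kg, the lowest of the three numbers; the gap to compound 2 is small, a 1.3-fold lower number from compound 2 to compound 3 (0.11 log units; within the scatter), while the gap to compound 1 is larger, a 2.5-fold lower number from compound 1 to compound 3 (0.40 log units; beyond the scatter).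

Compound 4, `CCCc1c(COc2ccc(C(=O)CC(C)(C)CC(=O)O)cc2)ccc(C(C)=O)c1O`, is not yet measured in this assay. It differs from compound 3 as follows: 1-(carboxymethyl)-1-methylethyl in place of 2-(1H-tetrazol-5-yl)ethyl on a saturated chain carbon bound to a carbonyl carbon. Going by the values given here, the change returns the acid function of compound 1 on a longer, branched chain without a tetrazole; no measured pair covers the chain branching itself.

Among the compounds with values here, the steps that bear on it are the acid-to-tetrazole exchanges: a 2.5-fold lower number from compound 1 to compound 3 (0.40 log units; beyond the scatter) and a 2.0-fold lower number from compound 1 to compound 2 (0.30 log units; within the scatter), the first beyond the scatter, the second within it. Reversing that exchange in compound 4 is therefore expected to move the number back up modestly, toward the value of compound 1, with the effect of the branched chain unknown.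

The expected step is a 1.9-fold higher number from compound 3 to compound 4 (0.29 log units; within the scatter). For compound 4 the estimate in this assay is 14 mg/kg, with a range of 6 mg/kg to 35 mg/kg.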

Compound 4, dose for half-maximal effect: 2.9 mg/kg
Beside the measured number, compound 4's estimate is 4.8-fold (0.68 log units) above it; the whole stated range lies above it.
By their numbers in this assay, from the lowest: compound 4; then compounds 3, 2 and 1 (each within the scatter of the next, the first and the last beyond it).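

In this assay, a tetrazole is not needed at this position: with 1-(carboxymethyl)-1-methylethyl in place of 2-(1H-tetrazol-5-yl)ethyl, the carboxylic acid gives a 2.5-fold lower number from compound 3 to compound 4 (0.39 log units; beyond the scatter), and against the methyl-branched tetrazole chain the step is a 3.2-fold lower number from compound 2 to compound 4 (0.50 log units; beyond the scatter). The chain bearing the acid also matters, since the acid-to-acid change from carboxymethyl to 1-(carboxymethyl)-1-methylethyl gives a 6.3-fold lower number from compound 1 to compound 4 (0.80 log units; beyond the scatter), the largest step in the series. No measurement shown accounts for this gain.

Added chain length and methyl branching arrive together in compound 4, so neither can be read alone. A straight-chain carboxylic acid of the same length would separate them, and a 1H-tetrazol-5-yl group on the branched chain would test the acid-to-tetrazole exchange there.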